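The source may hold more compounds than are shown below. What is called first, only, known or untested is meant among the compounds shown, and "the series" means these compounds.

In an assay on mitochondria from L6 cells (Rattus norvegicus) for activation, with a stated time of 90 min (a lower number here means that less compound is needed, a higher number that more compound is needed for the effect), compound 1 `Oc1nc2nonc2nc1Nc1ccccc1` gives 66700 nM. Among the measured compounds shown here, compound 2 `CCc1ccc(Nc2nc3nonc3nc2O)cc1` gives 10700 nM, and compound 3 `CCCCCc1ccc(Nc2nc3nonc3nc2O)cc1` gives 2400 nM, the lowest of the three numbers measured so far, with both other compounds beyond the scatter from it. Every measured step lengthens a carbon chain on the same ring: a 6.2-fold lower number from compound 1 to compound 2 (0.79 log units; beyond the scatter); a 28-fold lower number from compound 1 to compound 3 (1.44 log units; beyond the scatter); a 4.5-fold lower number from compound 2 to compound 3 (0.65 log units; beyond the scatter). Each of these changes lowered the number, and the longer chain did so more.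

Compound 4 `CCCCCc1ccc(Nc2nc3nonc3nc2O)c(F)c1` keeps the pentyl group of compound 3 and differs from it in one place: fluoro in place of hydrogen on an aromatic carbon. None of the three measured steps involves a fluoro or any other group of this kind, so nothing among them tells how this particular change will read out. The measured steps only show that a change on this ring can move the number by a modest to large amount. Without a step of the same kind to lean on, a change of no more than the usual scatter is the plainest expectation, and the expected step is a 1.2-fold lower number from compound 3 to compound 4 (0.08 log units; within the scatter). In this assay compound 4 is therefore estimated to give about 2000 nM, most likely between 600 nM and 6500 nM.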

Compound 4, half-maximal effective concentration: 1500 nM
For compound 4 the middle estimate is 1.3-fold (0.12 log units) above the measured one; the range from low to high includes it.
By their numbers in this assay, from the lowest: compounds 4 and 3 (each within the scatter of the next); then compound 2; then compound 1.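

In this assay the new step is a 1.6-fold lower number from compound 3 to compound 4 (0.20 log units; within the scatter), so compound 3 and compound 4 cannot be told apart here. The three earlier steps all lengthened a carbon chain and all ended beyond the scatter, whereas this change puts a single fluorine atom on an aromatic carbon, ortho to a large group and meta to a pentyl group, and it leaves the reading within the scatter, which shows that this place on the ring can carry a fluoro group with the pentyl group present and no measurable shift in the number. No measurement at hand explains why the fluoro group leaves the reading where it stands.

As far as these compounds go, a single fluoro group is only one case, so it remains open whether a chloro group, a methyl group, a methoxy group or an amine at this same place would also stay within the scatter. From the compounds shown here alone, it is equally open whether a fluoro group here would read the same alongside the ethyl group of compound 2, or alongside a longer chain such as octyl.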